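Ester Size and Calcium Channel Inhibition in One Series

The compounds below may be only part of what the source reports. "The series", "measured", "known", "first", "only" and "open" are said of these compounds alone.

Measured compounds:
compound 1 `COC(=O)C1=C(C)NC(C)=C(C(=O)OC)C1c1[nH]cnc1Cl` — 1200 nM
compound 2 `CC1=C(C(=O)OCC(C)C)C(c2[nH]cnc2Cl)C(C(=O)OCC(C)C)=C(C)N1` — 95.5 nM
compound 3 `CC1=C(C(=O)OC(C)(C)C)C(c2[nH]cnc2Cl)C(C(=O)OC(C)(C)C)=C(C)N1` — 4070 nM

Three compounds share one core and differ only in the ester groups attached to it. In an assay on isolated protein for inhibition of Voltage-dependent L-type calcium channel subunit alpha-1C (Cavia porcellus) (on this read-out higher numbers stand for weaker inhibition and lower numbers for stronger inhibition), compound 1 gives 1200 nM, the second highest of the three numbers. Compound 3 gives 4070 nM, a higher number than compound 1, and the gap lies beyond the scatter. Compound 2 gives 95.5 nM, a far lower number than compound 1, again well beyond the scatter. No pair of these compounds differs in a single place, so no single step can be read off directly; the numbers only show that replacing both methyl esters by isobutyl esters goes with much stronger inhibition, while tert-butyl esters go with weaker inhibition.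

Compound 4 `COC(=O)C1=C(C)NC(C)=C(C(=O)OCCc2ccccc2)C1c1[nH]cnc1Cl` is the unmeasured compound. It differs from compound 1 in one place: benzyl in place of hydrogen on a saturated chain carbon bound to an oxygen next to a carbonyl group. The change enlarges one ester with an unbranched chain carrying a ring, leaving the other ester as methyl. Among the measured compounds shown here, because compound 2 gives 95.5 nM with larger unbranched esters on both sides, a downward step is expected, but smaller than that seen for compound 2, since only one side changes. The expected step is a 3.4-fold lower number from compound 1 to compound 4 (0.54 log units; beyond the scatter). Compound 4 is therefore estimated at 350 nM, with a range from 100 nM to 1200 nM.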

Compound 4, half-maximal inhibitory concentration: 79.4 nM
Beside the measured number, compound 4's estimate is 4.4-fold (0.64 log units) above it; measured number outside the range, below it.
By their numbers in this assay, from the lowest: compounds 4 and 2 (each within the scatter of the next); then compound 1; then compound 3.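

In this assay, the change from methyl to phenethyl on one ester gives a 15-fold lower number from compound 1 to compound 4 (1.18 log units; beyond the scatter), a large step beyond the scatter and the first in this set that can be read at a single place. The earlier compounds shown here differ from one another in both esters at once, so they could not show what one ester does alone; here the second ester stays methyl, and changing the first is enough to bring a large gain in inhibition. No measurement shown here bears on why this enlargement goes with stronger inhibition.

As far as these compounds go, the step also does not separate the ring from the length of the chain, so it remains open whether an unbranched pentyl chain with no ring would go the same way, or whether a cyclohexyl or pyridine ring at the end of the chain would serve in place of the phenyl ring. Also open, from the compounds shown here alone, is what a dimethylamino group at the end of the chain would do, and whether phenethyl on the second ester as well would change the number further.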